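Naphthalen-1-yl for 3-methylphenyl on a shared core

A few compounds are considered here, and "the series" means these few. Any claim that something is new, unique, unknown or untested is made for them only; others in the source may bear on it.

Of the compounds shown here, three built on a shared core have been measured in a functional assay on CCRF-CEM cells (Homo sapiens) for inhibition, read by sulforhodamine B assay, with a stated time of 48 h, tested at 10 uM; a higher number here means more inhibition at the concentration tested (going by the name of the read-out), a lower number less inhibition. Compound 1 `Clc1ccc(-c2cn3ccnc3c(-c3ccc4ncn(C5CCCCC5)c4c3)n2)cc1` gives 11.4% in this assay. Compound 2 `Fc1ccccc1-c1cn2ccnc2c(-c2ccc3ncn(C4CCCCC4)c3c2)n1` gives 22.5% in this assay; the two differ in one place, and the step is a number 11.1 percentage points higher from compound 1 to compound 2 (beyond the scatter). Compound 3 `Cc1cccc(-c2cn3ccnc3c(-c3ccc4ncn(Cc5ccccc5)c4c3)n2)c1` gives 21.1% in this assay. Its number lies within the scatter of compound 2 and also within the scatter of compound 1, so the three compounds cannot be ordered on these measurements.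

Compound 4 `c1ccc(Cn2cnc3ccc(-c4nc(-c5cccc6ccccc56)cn5ccnc45)cc32)cc1` has not yet been measured in this assay. It differs from compound 3 in one place: naphthalen-1-yl in place of 3-methylphenyl on an aromatic carbon. For the measured compounds named here, only one measured step bears on this exchange of one group for another on an aromatic carbon of the shared core, the step from compound 1 to compound 2, and it was modest though beyond the scatter. It involves neither a 3-methylphenyl nor a naphthalen-1-yl group, so it gives no direct guide, and all three measured numbers sit in a narrow low band. One therefore expects no step beyond the scatter. Compound 4 is expected to give 20% in this assay, with a range from 5% to 38%. This expectation amounts to a number 1.1 percentage points lower from compound 3 to compound 4 (within the scatter).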

Compound 4, a percentage reported as inhibition, at one concentration (the size of the read-out at that concentration, not a potency): 6.22%
Compound 4: middle estimate off by 13.8 percentage points, on the high side, within the range that was stated.
By their numbers in this assay, from the lowest: compounds 4, 1, 3 and 2 (each within the scatter of the next, the first and the last beyond it).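

In this assay there is a number 14.9 percentage points lower from compound 3 to compound 4 (beyond the scatter), the first sign that enlarging the group at this aromatic carbon, from the single ring of 3-methylphenyl to the two rings of naphthalen-1-yl, can go with less inhibition on the core of compound 3. Set beside the earlier exchange at the same aromatic carbon, which was a number 11.1 percentage points higher from compound 1 to compound 2 (beyond the scatter), this shows that the number can move either way at this position, although the two steps stand on compounds that differ elsewhere and so cannot be read as one trend. Nothing measured here explains why naphthalen-1-yl goes with the lower number.

From the compounds shown here alone, it remains open whether the same exchange would give a similar step with the cyclohexyl group of compound 1 and compound 2 in place of the group carried by the ring nitrogen in compound 3 and compound 4. Going by these compounds, it is also open how a 4-aminophenyl, a pyridin-3-yl or a morpholine group at this aromatic carbon would read, and these single-concentration percentages say nothing about potency.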